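Replacing methylsulfonyl with aminomethyl on the pendant phenyl

The compounds below may be only part of what the source reports. "The series", "measured", "known", "first", "only" and "open" are said of these compounds alone.

Compound 1 `Cc1ccc2cnc(-c3ccccc3)nc2n1` carries an unsubstituted phenyl on the shared core and in a functional assay on CHO cells for antagonist activity at metabotropic glutamate receptor 5 (Rattus norvegicus), read by FLIPR and calcium flux (a lower number here means a stronger inhibitor, a higher number a weaker inhibitor), compound 1 gives 2700 nM. Compound 2 `Cc1ccc2cnc(-c3cccc(C#N)c3)nc2n1` adds a cyano group, and in this assay compound 2 gives 240 nM; the step is an 11-fold lower number from compound 1 to compound 2 (1.05 log units; beyond the scatter). Compound 3 `Cc1ccc2cnc(-c3cccc(S(C)(=O)=O)c3)nc2n1` carries methylsulfonyl instead. In this assay compound 3 sits at > 30000 nM, which is a limit and not a number (the limit of > 30000 nM in this assay, at which 1 of the 3 values shown sits). The measured steps into it were an at least 11-fold higher number from compound 1 to compound 3 (1.04 log units; beyond the scatter) and an at least 120-fold higher number from compound 2 to compound 3 (2.09 log units; beyond the scatter). Compound 4 `Cc1ccc2cnc(-c3cccc(CN)c3)nc2n1` differs from compound 3 by aminomethyl in place of methylsulfonyl on an aromatic carbon. Among the compounds with values here, both steps that brought methylsulfonyl in were large and upward, while no measured step shows aminomethyl itself, so the change is expected to lower the number, an at least 3.7-fold lower number from compound 3 to compound 4 (0.57 log units; beyond the scatter). Compound 4 is estimated at 8000 nM, within 1500 nM to 30000 nM.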

Compound 4, half-maximal inhibitory concentration: > 30000 nM
Compound 4: only a limit was reported; the forecaster's own chance of this, stated with the estimate: 35%; middle value at least 3.7-fold (0.57 log units) from the limit.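

In this assay, aminomethyl at this position gives an at least 120-fold higher number from compound 2 to compound 4 (2.09 log units; beyond the scatter) and an at least 11-fold higher number from compound 1 to compound 4 (1.04 log units; beyond the scatter), so it falls well short of both cyano and plain hydrogen. Of the three groups tried here, only cyano lowers the number, while methylsulfonyl and aminomethyl both raise it. The step between compound 3 and compound 4 cannot be read, because both stand at a limit: the limit of > 30000 nM in this assay, at which 2 of the 4 values shown sit.

Still open, going by these compounds, is how compound 3 and compound 4 rank against each other. Also open, on these data alone, is whether anything besides cyano gives a lower number here, such as chloro, methoxy or a longer chain ending in a nitrile.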